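This account rests on a few compounds, and the source may have more. Where it says the series, first, only, none or still open, it means among the compounds named here.

Two quinones of a shared core differ only in where the side chain sits. For the measured compounds named here, in a functional assay on AU565 cells (Homo sapiens) for cytotoxicity, read by MTT assay, with a stated time of 48 h (on this read-out higher numbers stand for weaker inhibition and lower numbers for stronger inhibition), compound 1 `COc1ccc(O)c2c1C(=O)C=C(CCC=C(C)C)C2=O` gives 880 nM, the lowest of the two numbers known. Compound 2 `COc1ccc(O)c2c1C(=O)C(CCC=C(C)C)=CC2=O` gives 7080 nM in this assay, a gap beyond the usual scatter. Compound 3 `COc1ccc(O)c2c1C(=O)C=C([C@H](CC=C(C)C)OC(C)=O)C2=O` keeps the core of compound 1 and differs from it by one change: acetoxy in place of hydrogen on a saturated chain carbon bound to a double-bonded ring carbon and a saturated chain carbon. Going by the values given here, no measured pair shows such a step, so in this assay the step from compound 1 to compound 3 is expected to be small, with no clear direction beyond the scatter: a 1.4-fold higher number from compound 1 to compound 3 (0.13 log units; within the scatter). Compound 3 is therefore estimated at 1200 nM, in a range from 400 nM to 4000 nM.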

Compound 3, half-maximal inhibitory concentration: 590 nM
Estimate against measurement, compound 3: 2.0-fold (0.31 log units) above; low and high end bracket the measured number.
By their numbers in this assay, from the lowest: compounds 3 and 1 (each within the scatter of the next); then compound 2.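

In this assay, acetoxy in place of hydrogen on a saturated chain carbon bound to a double-bonded ring carbon and a saturated chain carbon gives a 1.5-fold lower number from compound 1 to compound 3 (0.17 log units; within the scatter). For the compounds shown here, this is the first reading of a change on the side chain itself, and this chain carbon takes the acetoxy without a difference that stands clear of the scatter. Nothing given here accounts for this result. The compounds shown leave open whether a hydroxyl or an amine at this carbon would read the same, and whether acetoxy would behave alike on the side chain of compound 2.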